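This account rests on a few compounds, and the source may have more. Where it says the series, first, only, none or still open, it means among the compounds named here.

Measured compounds:

Compound 1, `Cc1cc(Cl)nnc1N1CCN(c2ncccn2)CC1`. In a functional assay on BV-2 cells (Mus musculus) for inhibition, read by ELISA, with a stated time of 16 h (a lower number here means a stronger inhibitor, a higher number a weaker inhibitor), compound 1 gives > 100000 nM, which is a limit of the assay and not a number.
Compound 2, `Cc1cc(-c2cccnc2)nnc1N1CCN(c2ncccn2)CC1`. Compound 2 gives > 100000 nM, again a limit.
Compound 3, `Cc1cc(-c2ccncc2)nnc1N1CCN(c2ncccn2)CC1`. Compound 3 gives > 100000 nM, also a limit.

Compound 1 therefore stands nowhere readable on the scale: it sits at the limit, and the two other values shown sit at the same limit (the limit of > 100000 nM in this assay, at which 3 of the 3 values shown sit). The three steps between the measured compounds, a step that the two limits leave unreadable from compound 1 to compound 2, a step that the two limits leave unreadable from compound 1 to compound 3 and a step that the two limits leave unreadable from compound 2 to compound 3, are all unreadable in size, since each end of each step is a limit.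

Compound 4 is `Cc1cc(-c2cc3ccccc3s2)nnc1N1CCN(c2ncccn2)CC1`. It differs from compound 1 as follows: 1-benzothiophen-2-yl in place of chloro on an aromatic carbon. The measured steps that bear on this change are those from the chloro of compound 1 to the pyridin-3-yl of compound 2 and the pyridin-4-yl of compound 3, and neither gives a size, so no direction and no size beyond the scatter can be read for a change at the same aromatic carbon.

The working expectation for compound 4 is a step of a number no higher from compound 1 to compound 4 (the limit leaves the size open), with the result most likely again a limit. The estimate for compound 4 is 100000 nM, in the range 5000 nM to 500000 nM.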

Compound 4, half-maximal inhibitory concentration: 24900 nM
Compound 4: the middle estimate sits 4.0-fold (0.60 log units) above what was measured, and the stated range covers the measured number.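

In this assay, among these compounds, 1-benzothiophen-2-yl in place of chloro on the aromatic carbon next to the ring nitrogen gives an at least 4.0-fold lower number from compound 1 to compound 4 (0.60 log units; beyond the scatter), the first sign that a change at this position can bring the read-out off the limit. A ring at this carbon is not enough by itself, as the replacement of the two pyridine groups gives an at least 4.0-fold lower number from compound 3 to compound 4 (0.60 log units; beyond the scatter) and an at least 4.0-fold lower number from compound 2 to compound 4 (0.60 log units; beyond the scatter). These three sizes are floors and not exact differences, because one end of each step is a limit: the limit of > 100000 nM in this assay, at which 3 of the 4 values shown sit.

From the compounds shown here alone, the steps among compounds 1, 2 and 3 stay unreadable, so the chloro and the two pyridine groups cannot be ordered, and the full size of the change to 1-benzothiophen-2-yl remains unknown. The compounds shown also do not separate the contribution of the sulfur from that of the fused carbon ring, a question that phenyl, thiophen-2-yl or naphthalen-2-yl at the same carbon would address.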